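Benzyloxy-phenyl isoxazole series: methoxy pattern on the benzyl ring

The compounds below may be only part of what the source reports. "The series", "measured", "known", "first", "only" and "open" are said of these compounds alone.

Measured so far:
Compound 1 `Fc1ccccc1COc1ccc(-c2cc(CN3CCN(Cc4ccc(C(F)(F)F)cc4)CC3)no2)cc1` gives 1500 nM in a functional assay on Huh-7 cells (Homo sapiens) for antiproliferative activity, read by sulforhodamine B assay, with a stated time of 72 h; on this read-out lower numbers stand for stronger inhibition and higher numbers for weaker inhibition.
Compound 2 `COc1ccccc1COc1ccc(-c2cc(CN3CCN(Cc4ccc(C(F)(F)F)cc4)CC3)no2)cc1` gives 900 nM in this assay.

Going by the values given here, compound 2 holds the lowest of the two numbers, but its only neighbour is compound 1, and the step of a 1.7-fold lower number from compound 1 to compound 2 (0.22 log units; within the scatter) is within the scatter. Compound 3 `COc1cc(COc2ccc(-c3cc(CN4CCN(Cc5ccc(C(F)(F)F)cc5)CC4)no3)cc2)cc(OC)c1` carries 3,5-dimethoxyphenyl in place of 2-methoxyphenyl on a saturated chain carbon bound to an oxygen on an aromatic ring. Among the compounds with values here, no measured step bears on this change directly; the one step recorded, from compound 1 to compound 2, alters a substituent on the same ring and stays within the scatter. No step beyond the scatter is therefore expected in this assay for compound 3, which is estimated at 1000 nM (range 400 nM to 2500 nM), a step of a 1.1-fold higher number from compound 2 to compound 3 (0.05 log units; within the scatter).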

Compound 3, half-maximal inhibitory concentration: 1500 nM
Compound 3: middle estimate off by 1.5-fold (0.18 log units), on the low side, and the stated range covers the measured number.
By their numbers in this assay, from the lowest: compounds 2, 1 and 3 (each within the scatter of the next).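

At this place, on a saturated chain carbon bound to an oxygen on an aromatic ring, 3,5-dimethoxyphenyl in place of 2-methoxyphenyl gives a 1.7-fold higher number from compound 2 to compound 3 (0.22 log units; within the scatter) in this assay and in place of 2-fluorophenyl gives no change at the digits printed from compound 1 to compound 3 (within the scatter) as its reading. The three aryl groups shown at this place are therefore not told apart by this assay, even with a second methoxy group present. Nothing at hand offers an explanation for this reading. Still open, from the compounds shown here alone, is whether an amine or a carboxylic acid on this ring, or a longer chain at this place, would give a step beyond the scatter.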